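The source may report more compounds than this note shows. Statements on the series, on what has been measured and on what is new or still open speak of the compounds shown alone.

Working notes on the sulfonyl-lactam series in a functional assay on MDA-MB-231 cells (Homo sapiens) for antiproliferative activity, read by fluorescence and SYBR Green assay, with a stated time of 24 h; on this read-out higher numbers stand for weaker inhibition and lower numbers for stronger inhibition.

Compound 1 `CCCN(c1ccccc1)S(=O)(=O)c1ccc(N2CCCC2=O)cc1` reaches only the limit of > 5000 nM in this assay, a limit and not a number, as the limit of > 5000 nM in this assay, at which 1 of the 3 values shown sits, records. Compound 2 `CN1CCN(S(=O)(=O)c2ccc(N3CCCC3=O)cc2)c2ccccc21` gives 13 nM in this assay. Compound 3 `COc1ccc2c(c1)CCCN2S(=O)(=O)c1ccc(N2CCCC2=O)cc1` gives 20 nM in this assay, a value lying within the scatter of that of compound 2, so the two cannot be ordered; of the two numbers given, that of compound 3 is the higher one.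

Compound 4 `Cc1ccc2c(c1)CCCN2S(=O)(=O)c1ccc(N2CCCC2=O)cc1` awaits measurement. It differs from compound 3 by methyl in place of methoxy on an aromatic carbon. Among the compounds with values here, no step between measured compounds bears on this exchange. The expected step from compound 3 to compound 4 in this assay is a 1.3-fold higher number from compound 3 to compound 4 (0.10 log units; within the scatter), not beyond the scatter in either direction. Compound 4 is therefore estimated at 25 nM, in the range from 8 nM to 80 nM.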

Compound 4, half-maximal inhibitory concentration: 17 nM
Compound 4: middle estimate off by 1.5-fold (0.17 log units), on the high side, within the range that was stated.
By their numbers in this assay, from the lowest: compounds 2, 4 and 3 (each within the scatter of the next). At a limit, above all of these: compound 1.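

In this assay, methyl in place of methoxy on this aromatic carbon gives a 1.2-fold lower number from compound 3 to compound 4 (0.07 log units; within the scatter), so compounds 3 and 4 cannot be ordered. The oxygen and the hydrogen-bond acceptor that leave with the methoxy are therefore not required at this position for a value of this size. No measurement on hand gives a reason for this result.

Still open, on these data alone, is how an amine, a carboxylic acid or a longer chain such as butoxy would read at this aromatic carbon. Also open, as far as these compounds go, is whether methyl reads the same on the other carbons of that ring.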